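The source may hold more compounds than are shown below. What is called first, only, known or untested is meant among the compounds shown, and "the series" means these compounds.

Measured so far in a functional assay on A549 cells (Homo sapiens) for inhibition, read by MTT assay, with a stated time of 72 h, tested at 20 uM; a lower number here means less inhibition, a higher number more inhibition at the concentration tested (going by the name of the read-out):
compound 1 `c1cc(N2CCCCC2)nc(Nc2ccc(Oc3ncnc4sccc34)cc2)n1` gives 64.8%
compound 2 `c1ccc2c(c1)CCN(c1ccnc(Nc3ccc(Oc4ncnc5sccc45)cc3)n1)C2` gives 34%

Compound 2 holds the lower of the two numbers in this assay, set apart from compound 1 by the step of a number 30.8 percentage points lower from compound 1 to compound 2 (beyond the scatter). Compound 3 `c1ccc2c(c1)CCN2c1ccnc(Nc2ccc(Oc3ncnc4sccc34)cc2)n1` differs from compound 2 by 2,3-dihydro-1H-indol-1-yl in place of 1,2,3,4-tetrahydroisoquinolin-2-yl on an aromatic carbon. Within the data shown here, no measured step exchanges one bicyclic amine for another; the only step known, a number 30.8 percentage points lower from compound 1 to compound 2 (beyond the scatter), concerns the loss of the piperidin-1-yl and does not speak to this smaller change. The step of a number 4 percentage points higher from compound 2 to compound 3 (within the scatter) is therefore expected to remain within the scatter. Compound 3 is estimated at 38%, in the range 20% to 58%.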

Compound 3, a percentage reported as inhibition, at one concentration (the size of the read-out at that concentration, not a potency): 2.81%
Compound 3: middle estimate off by 35.2 percentage points, on the high side, outside the stated range (below it).
By their numbers in this assay, from the lowest: compound 3; then compound 2; then compound 1.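

At this position in this assay, the two bicyclic amines are not interchangeable: the five-membered non-aromatic ring of 2,3-dihydro-1H-indol-1-yl, in place of the six-membered one of 1,2,3,4-tetrahydroisoquinolin-2-yl, gives a number 31.2 percentage points lower from compound 2 to compound 3 (beyond the scatter), a gap the earlier pair could not reveal. Against piperidin-1-yl, the same group gives a number 62 percentage points lower from compound 1 to compound 3 (beyond the scatter), the widest step in the series. No available evidence accounts for either step.

Open, from the compounds shown here alone, is whether pyrrolidin-1-yl, a five-membered ring without the fused benzene ring, would also stand low, and how morpholin-4-yl would compare with piperidin-1-yl.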